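This account rests on a few compounds, and the source may have more. Where it says the series, first, only, none or still open, it means among the compounds named here.

In an ADME assay on Vero cells (Chlorocebus sabaeus) for cytotoxicity, read by MTT assay (a higher number here means that more compound is tolerated, a lower number that less compound is tolerated), compound 2 `Cn1nc(C(F)(F)F)cc1C(=O)Nc1ccc(S(=O)(=O)NC2CCCCC2)cc1` gives 15000 nM. Compound 3 `Cn1nc(C(F)(F)F)cc1C(=O)Nc1ccc(S(=O)(=O)N2CCCCC2CO)cc1` gives 159000 nM, the higher of the two numbers. Compound 1 `Cn1nc(C(F)(F)F)cc1C(=O)Nc1ccc(S(=O)(=O)N2CCC[C@H]2C(=O)O)cc1` reads > 300000 nM, which is a limit of the assay and not a number. Compound 4 `Cn1nc(C(F)(F)F)cc1C(=O)Nc1ccc(S(=O)(=O)N2CCC(O)CC2)cc1` carries 4-hydroxypiperidin-1-yl in place of 2-(hydroxymethyl)piperidin-1-yl on the sulfonyl sulfur: 4-hydroxypiperidin-1-yl in place of 2-(hydroxymethyl)piperidin-1-yl on a sulfonyl sulfur. Two measured steps at this place bear on the change: the large 11-fold higher number from compound 2 to compound 3 (1.03 log units; beyond the scatter), and an at least 1.8-fold lower number from compound 1 to compound 3 (0.27 log units; that floor lies within the scatter). The large step starts from cyclohexylamino, whereas compound 4 keeps a hydroxy-bearing piperidin-1-yl group, so no comparable shift is expected in this assay. The expected change is a 1.0-fold higher number from compound 3 to compound 4 (0.00 log units; within the scatter), not beyond the scatter. For compound 4 the estimated value is 160000 nM, with an expected range of 70000 nM to 300000 nM.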

Compound 4, half-maximal cytotoxic concentration: 274000 nM
Compound 4: middle estimate off by 1.7-fold (0.23 log units), on the low side, within the range that was stated.
By their numbers in this assay, from the lowest: compound 2; then compounds 3 and 4 (each within the scatter of the next). At a limit, above all of these: compound 1.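

In this assay, 4-hydroxypiperidin-1-yl in place of 2-(hydroxymethyl)piperidin-1-yl on the sulfonyl sulfur gives a 1.7-fold higher number from compound 3 to compound 4 (0.24 log units; within the scatter). The large gain over cyclohexylamino therefore holds for a second hydroxy-bearing piperidin-1-yl group: an 18-fold higher number from compound 2 to compound 4 (1.26 log units; beyond the scatter). The step from compound 1 cannot be read, because compound 1 stands at a limit and has no number: the limit of > 300000 nM in this assay, at which 1 of the 4 values shown sits. All that can be printed for this step is a floor: an at least 1.0-fold lower number from compound 1 to compound 4 (0.03 log units; that floor lies within the scatter).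

Still open, on these data alone, is whether a plain piperidin-1-yl group without hydroxy would read with compound 2 or with compounds 3 and 4. The same question holds for a 4-aminopiperidin-1-yl group at this sulfur.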